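Tail variation on the spiro series: compound 4 pending

The source may report more compounds than this note shows. Statements on the series, on what has been measured and on what is new or still open speak of the compounds shown alone.

Measured so far in an assay on HEK293 cells for displacement of a labelled ligand from NPC1-like intracellular cholesterol transporter 1 (Homo sapiens); a higher number here means a weaker inhibitor, a lower number a stronger inhibitor:
compound 1 `O=C(CN1CN(c2ccccc2)C2(CCN(C(=O)c3ccc(C4CCCCC4)cc3)CC2)C1=O)NCCCCO` gives 10300 nM;
compound 2 `COC(=O)CCNC(=O)CN1CN(c2ccccc2)C2(CCN(C(=O)c3ccc(C4CCCCC4)cc3)CC2)C1=O` gives 12900 nM;
compound 3 `CC(C)(C)c1ccc(C(=O)N2CCC3(CC2)C(=O)N(CC(=O)NCCC(=O)O)CN3c2ccccc2)cc1` gives 11400 nM.

Compound 3 stands second highest of the three numbers, its nearest neighbour being compound 1 and its furthest compound 2, both gaps within the scatter; the three values are not separable. Compound 4 `CC(C)(C)c1ccc(C(=O)N2CCC3(CC2)C(=O)N(CC(=O)NCNS(C)(=O)=O)CN3c2ccccc2)cc1` differs from compound 3 at the tail: methanesulfonamido in place of carboxymethyl on a saturated chain carbon bound to an amide-type nitrogen. Within the data shown here, the only measured step on this part of the series is a 1.3-fold higher number from compound 1 to compound 2 (0.10 log units; within the scatter), a tail change that left the number where it was; it does not involve a methanesulfonamido group, so it is only a loose guide. No step beyond the scatter is expected, a 1.1-fold higher number from compound 3 to compound 4 (0.02 log units; within the scatter). Compound 4 is estimated at 12000 nM in this assay, in the range 5000 nM to 30000 nM.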

Compound 4, half-maximal inhibitory concentration: 3200 nM
Compound 4: middle estimate off by 3.8-fold (0.57 log units), on the high side; measured number below the stated range.
By their numbers in this assay, from the lowest: compound 4; then compounds 1, 3 and 2 (each within the scatter of the next).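

The tail position does respond in this assay: methanesulfonamido in place of carboxymethyl on a saturated chain carbon bound to an amide-type nitrogen gives a 3.6-fold lower number from compound 3 to compound 4 (0.55 log units; beyond the scatter) as a modest step beyond the scatter. Among these compounds, the only earlier tail change, on a different core, gave a 1.3-fold higher number from compound 1 to compound 2 (0.10 log units; within the scatter) and stayed within the scatter. No available evidence bears on the origin of this step.

Open, from the compounds shown here alone, is whether an amine or a longer chain ending in methanesulfonamido would keep the lower number at this position. Also open, going by these compounds, is whether methanesulfonamido gives a similar step on the core of compound 1.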